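Working notes: 2-methoxyphenyl in place of 3-chlorophenyl

This account rests on a few compounds, and the source may have more. Where it says the series, first, only, none or still open, it means among the compounds named here.

Measured so far in a functional assay on OVCAR-3 cells (Homo sapiens) for inhibition, read by MTT assay, with a stated time of 24 h; on this read-out higher numbers stand for weaker inhibition and lower numbers for stronger inhibition:
compound 1 `CC1(C)[C@H]2CC[C@]1(C)N(Cc1cn(-c3ccc(C#N)cc3)nn1)C(=O)C2` gives 380 nM
compound 2 `CC1(C)[C@H]2CC[C@]1(C)N(Cc1cn(-c3cccc(Cl)c3)nn1)C(=O)C2` gives 50 nM

Compound 2 holds the lower of the two numbers, and its gap to compound 1 lies beyond the scatter. The next structure is compound 3 `COc1ccccc1-n1cc(CN2C(=O)C[C@@H]3CC[C@@]2(C)C3(C)C)nn1`, with 2-methoxyphenyl in place of 3-chlorophenyl on an aromatic nitrogen of a five-membered aromatic ring with 3 nitrogen. The counted difference reads 2-methoxyphenyl in place of 3-chlorophenyl on an aromatic nitrogen and leaves the shared core untouched.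

Among the compounds with values here, only one measured step bears on this change, a 7.6-fold lower number from compound 1 to compound 2 (0.88 log units; beyond the scatter) on replacing 4-cyanophenyl with 3-chlorophenyl, and it is modest in size. Within the data shown here, it shows that the group on this nitrogen can move the number in this assay, but no measured compound carries a methoxy group. Among the measured compounds shown here, with compound 2 at 50 nM as the lower of only two values, a step of similar or smaller size towards a higher number is expected, not a further fall. The expected step is a 3.0-fold higher number from compound 2 to compound 3 (0.48 log units; beyond the scatter) with wide uncertainty. For compound 3 the estimate is an expected value of 150 nM (range 40 nM to 600 nM).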

Compound 3, half-maximal inhibitory concentration: 140 nM
Beside the measured number, compound 3's estimate is 1.1-fold (0.03 log units) above it, within the range that was stated.
By their numbers in this assay, from the lowest: compound 2; then compound 3; then compound 1.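

In this assay, the 2-methoxyphenyl group gives a 2.8-fold higher number from compound 2 to compound 3 (0.45 log units; beyond the scatter), but also a 2.7-fold lower number from compound 1 to compound 3 (0.43 log units; beyond the scatter), so the new group sits inside the span set by the two earlier aryl groups and does not extend it. The three compounds now fall into a clear order, with compound 2 lowest, then compound 3, then compound 1, and every step among them is beyond the scatter; this nitrogen therefore accepts a group bearing a hydrogen-bond acceptor while keeping a nanomolar number, though not the lowest one so far. Nothing measured here explains this order or accounts for the size of these steps.

Each of the three aryl groups differs from the others in both its substituent and where that substituent sits on the phenyl ring, so the two effects cannot yet be separated. Also open, from the compounds shown here alone, is how the number would respond to a phenyl ring with no further group, or to one carrying an amine or a carboxylic acid, and whether any such group would fall below compound 2 at 50 nM.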